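The compounds below may be only part of what the source reports. "The series", "measured", "known", "first", "only" and "open" are said of these compounds alone.

Measured compounds in an assay on isolated protein for inhibition of protein kinase C zeta type (Homo sapiens), read by 33P incorporation, tested at 200 uM; on this read-out lower numbers stand for a weaker effect and higher numbers for a stronger effect at the one concentration tested:
- compound 1, `O=C(O)CC(Cc1nc2cc(C(F)(F)F)ccc2[nH]1)c1ccc(Cl)cc1`, compound 1 gives 85%
- compound 2, `Cc1ccc2[nH]c(CC(CC(=O)O)c3ccc(Cl)cc3)nc2c1`, compound 2 gives 0%

Within the data shown here, compound 2 stands lowest of the two numbers in this assay; its nearest neighbour is compound 1, and the single step between them, a number 85 percentage points lower from compound 1 to compound 2 (beyond the scatter), came with methyl in place of trifluoromethyl on an aromatic carbon.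

Compound 3, `O=C(O)CC(Cc1nc2cc(C(=O)O)ccc2[nH]1)c1ccc(Cl)cc1`, is not yet measured in this assay. It differs from compound 2 as follows: carboxy in place of methyl on an aromatic carbon. Among the measured compounds shown here, no measured step has a carboxy group entering or leaving on this ring, so the only step in hand, a number 85 percentage points lower from compound 1 to compound 2 (beyond the scatter), bears on it just by showing that a change at this aromatic carbon can move the number across most of the scale. The direction for compound 3 cannot be read from that step, and the expectation is accordingly wide. Compound 3 is estimated at 30% in this assay, with a range of 0% to 75%, which is expected to mean a step of a number 30 percentage points higher from compound 2 to compound 3 (beyond the scatter).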

Compound 3, a percentage reported as inhibition, at one concentration (the size of the read-out at that concentration, not a potency): 0%
Compound 3: the middle estimate sits 30 percentage points above what was measured, within the range that was stated.
By their numbers in this assay, from the lowest: compounds 2 and 3 (each within the scatter of the next); then compound 1.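

In this assay, trifluoromethyl on this aromatic carbon now has a second replacement that goes against it: carboxy brings a number 85 percentage points lower from compound 1 to compound 3 (beyond the scatter) and so matches the loss already seen with methyl. Methyl and carboxy are not separated at the one concentration tested, with no change at the digits printed from compound 2 to compound 3 (within the scatter) as the reading, so a group that brings a hydrogen-bond donor and a hydrogen-bond acceptor to this carbon recovers none of the effect held by compound 1. Nothing measured on the series accounts for the gap between trifluoromethyl and these two replacements.

Still open, from the compounds shown here alone, is whether the effect is confined to trifluoromethyl among groups on this carbon, or would also appear with chloro, nitrile or methoxy there. Also open, going by these compounds, is what the side-chain carboxylic acid shared by all three compounds contributes, a question that a methyl ester or an amide in its place on the core of compound 1 would address.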